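Ether substituent at the shared core: compound 2 to compound 4

The source may report more compounds than this note shows. Statements on the series, on what has been measured and on what is new or still open speak of the compounds shown alone.

Compound 1 `C=CCOc1ccc2c(=O)c(-c3cc(OC)c(OC)cc3OC)coc2c1` gives 6600 nM in a functional assay on HCT-116 cells (Homo sapiens) for antiproliferative activity, read by MTT assay, with a stated time of 24 h; on this read-out higher numbers stand for weaker inhibition and lower numbers for stronger inhibition.
Compound 3 `COc1cc(OC)c(-c2coc3cc(OCc4ccc(Br)cc4)ccc3c2=O)cc1OC` gives 1980 nM in this assay.
Compound 2 `COc1cccc(C(=O)Oc2ccc3c(=O)c(-c4cc(OC)c(OC)cc4OC)coc3c2)c1` gives > 10000 nM in this assay, a limit of the assay and not a number.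

Compound 2 therefore stands at the limit of > 10000 nM in this assay, at which 1 of the 3 values shown sits; only a limit is known for it, and no number. Compound 4 `COc1cc(OC)c(-c2coc3cc(OCc4cccc(F)c4)ccc3c2=O)cc1OC` differs from compound 2 by 3-fluorobenzyl in place of (3-methoxyphenyl)carbonyl on an oxygen on an aromatic ring. The measured step that bears most directly on this change is an at least 5.0-fold lower number from compound 2 to compound 3 (0.70 log units; beyond the scatter), where the same carbonyl-bearing group is likewise exchanged for a halogen-bearing benzyl group on the same oxygen. Further, a 3.3-fold lower number from compound 1 to compound 3 (0.52 log units; beyond the scatter) places the benzyl ether of compound 3 beyond the scatter from the allyl ether of compound 1. A step of comparable size in this assay, towards a lower number, is expected here. Compound 4 is expected to give 2500 nM, within a range of 1000 nM to 7000 nM. The expected step is an at least 4.0-fold lower number from compound 2 to compound 4 (0.60 log units; beyond the scatter).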

Compound 4, half-maximal inhibitory concentration: 4920 nM
Compound 4: the middle estimate sits 2.0-fold (0.29 log units) below what was measured; the measured number falls inside the stated range.
By their numbers in this assay, from the lowest: compound 3; then compounds 4 and 1 (each within the scatter of the next). At a limit, above all of these: compound 2.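

At the oxygen on an aromatic ring, the substituent on the benzyl group matters: in this assay there is a 2.5-fold higher number from compound 3 to compound 4 (0.40 log units; beyond the scatter) for 3-fluorophenyl in place of 4-bromophenyl, while the allyl ether shows a 1.3-fold lower number from compound 1 to compound 4 (0.13 log units; within the scatter) and so a benzyl ether alone does not carry the gain seen with 4-bromobenzyl. Exchange of the ester for 3-fluorobenzyl gives an at least 2.0-fold lower number from compound 2 to compound 4 (0.30 log units; that floor lies within the scatter) and so sets only a weak floor. Compound 2 remains a limit of the assay and not a number: the limit of > 10000 nM in this assay, at which 1 of the 4 values shown sits.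

Going by these compounds, whether the difference between the two benzyl ethers follows the halogen or its place on the ring stays open, since both change together. On these data alone, how an amine or a carboxylic acid on the benzyl ring would read at this oxygen also stays open.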